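The compounds below may be only part of what the source reports. "The series", "measured", "known", "first", "only" and "open" are said of these compounds alone.

Measured compounds in an in vitro functional assay on HEK285-7 cells for antagonist activity at prostaglandin D2 receptor 2 (Homo sapiens), read by BRET and beta-arrestin recruitment; a lower number here means a smaller maximal response, a higher number a larger maximal response:

compound 1, `O=C(O)Cc1sc(Cc2ccccc2)nc1-c1ccc(Cl)cc1`, 50%
compound 2, `O=C(O)Cc1sc(C(c2ccccc2)c2ccccc2)nc1-c1ccccc1`, 80%
compound 3, `O=C(O)Cc1sc(C(c2ccc(F)cc2)c2ccc(F)cc2)nc1-c1ccnc(N2CCC2)c1`, 80%

Compound 3 stands level with compound 2 at the digits shown; together they give the highest of the three maximal responses. Compound 1 sits lower than compound 3, a gap beyond the usual scatter. Going by the values given here, compound 2 and compound 3 differ in more than one place, so the data show only that their two values coincide within the scatter.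

Compound 4, `O=C(O)Cc1sc(C(c2ccc(F)cc2)c2ccc(F)cc2)nc1-c1cccc(F)c1`, arises from compound 3 by one change:

3-fluorophenyl in place of 2-(azetidin-1-yl)pyridin-4-yl on an aromatic carbon

Among the compounds with values here, no single-point step between measured compounds is available for this kind of change. Since compound 2, carrying a plain phenyl at this position, matches compound 3 in this assay, the author expects the step of a number 2 percentage points lower from compound 3 to compound 4 (within the scatter) to be small, with no change beyond the scatter in either direction. For compound 4 the expected maximal response is therefore 78%, with a likely range from 60% to 92%.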

Compound 4, largest response reached (reported as efficacy), in percent of the reference or control that the assay uses: 80%
The estimate for compound 4 lay 2 percentage points below the measured number; low and high end bracket the measured number.
By their numbers in this assay, from the lowest: compound 1; then compounds 2, 3 and 4 (each within the scatter of the next).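

In this assay, replacing 2-(azetidin-1-yl)pyridin-4-yl with 3-fluorophenyl on the aromatic carbon next to the ring nitrogen gives no change at the digits printed from compound 3 to compound 4 (within the scatter) and is the only step shown that changes this position alone. It shows that the maximal response stays within the scatter when the four-membered non-aromatic ring, both nitrogens and the hydrogen-bond acceptors of the leaving group are all gone, and a fluorine enters. The entering ring is carbon only, so neither a ring nitrogen nor the azetidine is needed here to reach this level of response. Nothing measured here explains why the two groups read alike.

The compounds shown leave open whether a methyl group or an open-chain dimethylamino group at this position would hold the same response. They also leave open whether this exchange would behave the same with the other large group of the shared core changed.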